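The compounds below may be only part of what the source reports. "The series", "measured", "known", "first", "only" and "open" are said of these compounds alone.

Working notes on the series. Compound 1 `O=C(N[C@H]1CCC[C@H](CO)C1)C1CCN(c2nc3cc(Cl)c(Cl)cc3o2)CC1` carries two chloro groups on the shared core, and in an ADME assay on microsomes from liver (Homo sapiens) for metabolic stability (a lower number here means slower removal, a higher number faster removal of the compound), compound 1 gives 27.1 mL/min/kg. Compound 2 `O=C(N[C@H]1CCC[C@H](CO)C1)C1CCN(c2nc3cc(Br)ccc3o2)CC1` carries a single bromo in their place; in this assay compound 2 gives 25.6 mL/min/kg, the lowest of the two numbers on record, with compound 1 nearest at 27.1 mL/min/kg, a gap within the scatter, so the two stand level. Compound 3 `CCOc1ccc(-c2cc3oc(N4CCC(C(=O)N[C@H]5CCC[C@H](CO)C5)CC4)nc3cc2Cl)cc1` carries a 4-ethoxyphenyl group. In this assay compound 3 gives < 8 mL/min/kg, which is a limit of the assay rather than a number. Going by the values given here, the one measured step, an at least 3.3-fold lower number from compound 1 to compound 3 (0.52 log units; beyond the scatter), rests on that limit of < 8 mL/min/kg in this assay, at which 1 of the 3 values shown sits, and so marks only a lower bound for its size.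

Compound 4 `N#Cc1ccc2oc(N3CCC(C(=O)N[C@H]4CCC[C@H](CO)C4)CC3)nc2c1` differs from compound 2 by cyano in place of bromo on an aromatic carbon. Among the compounds with values here, no measured step exchanges one substituent for another at this position in the way the present change does: the only step on record swaps chloro for 4-ethoxyphenyl and ends at a limit, so it gives no size for the bromo-to-cyano change. The expectation therefore stays close to compound 2. The expected step, a 1.3-fold lower number from compound 2 to compound 4 (0.11 log units; within the scatter), is estimated to stay within the scatter. In this assay compound 4 is expected to give 20 mL/min/kg, with a range from 10 mL/min/kg to 36 mL/min/kg.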

Compound 4, clearance: < 8 mL/min/kg
Compound 4: no number, only a limit; the forecaster's own chance of this, stated with the estimate: 15%; middle value at least 2.5-fold (0.39 log units) away from the limit.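

In this assay, exchanging bromo for cyano on this aromatic carbon gives an at least 3.2-fold lower number from compound 2 to compound 4 (0.50 log units; beyond the scatter), so a change of one small substituent at this position already moves the read-out beyond the scatter. Going by these compounds alone, until now, the only step beyond the scatter on record was the one that put the much larger 4-ethoxyphenyl group on the shared core, and the present change adds no ring and no net charge. Compound 4 gives < 8 mL/min/kg, which is a limit of the assay and not a number, so the step marks only a lower bound for its size: the limit of < 8 mL/min/kg in this assay, at which 2 of the 4 values shown sit.

From the compounds shown here alone, how far compound 3 and compound 4 each lie past that limit cannot be read, so the two cannot be placed in order, and the true size of the step from bromo to cyano stays unknown. Whether this low reading belongs to cyano alone also stays open, as the compounds shown hold no other replacement at this position, such as an amine, a carboxylic acid or a methoxy group, for comparison with bromo.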